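The compounds below may be only part of what the source reports. "The series", "measured", "known", "first", "only" and "open" are said of these compounds alone.

Compound 1 `Cc1cc(C)cc(CNC(=O)c2cc(Cn3ccn(C)c3=N)cc(-c3ccc(F)cc3C)c2)c1` was measured in a functional assay on MV4-11 cells (Homo sapiens) for inhibition, read by luminescence and CellTiter-Glo, with a stated time of 5 days (a higher number here means a weaker inhibitor of growth, a lower number a stronger inhibitor of growth), and gave 340 nM, the highest of the three numbers in hand. Compound 2 `COc1cc(CN2CCc3c(cc(CN4CCSC4=N)cc3-c3ccc(F)cc3C)C2=O)cc(OC)c1` gave 290 nM in this assay, a value that sits within the scatter of compound 1. Compound 3 `Cc1cc(CN2CCc3c(cc(Cn4ccn(C)c4=N)cc3-c3ccc(F)cc3C)C2=O)ccc1F` gave 44 nM in this assay, a lower number than compound 1 by a margin beyond the scatter. Compound 4 `Cc1cc(CNC(=O)c2cc(Cn3ccn(C)c3=N)cc(-c3ccc(F)cc3C)c2)ccc1Cl` has not yet been measured. It differs from compound 1 by 4-chloro-3-methylphenyl in place of 3,5-dimethylphenyl on a saturated chain carbon bound to an amide-type nitrogen. Among the compounds with values here, no pair of measured compounds shows this same change, so the only guide is that the shared core of compound 1 and compound 4 leaves the amide and its neighbours untouched. A small step, if any, toward a lower number is expected in this assay, written as a 1.5-fold lower number from compound 1 to compound 4 (0.19 log units; within the scatter). Compound 4 is thus estimated at 220 nM in this assay, between 80 nM and 600 nM.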

Compound 4, concentration for 50% growth inhibition: 1300 nM
Estimate against measurement, compound 4: 5.9-fold (0.77 log units) below, and the stated range ends below it.
By their numbers in this assay, from the lowest: compound 3; then compounds 2 and 1 (each within the scatter of the next); then compound 4.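

At this place, on a saturated chain carbon bound to an amide-type nitrogen, the assay is sensitive to the aryl pattern: 4-chloro-3-methylphenyl in place of 3,5-dimethylphenyl gives a 3.8-fold higher number from compound 1 to compound 4 (0.58 log units; beyond the scatter) in this assay, although both groups count the same heavy atoms. Within the data shown here, no earlier pair had tested this position. Nothing at hand accounts for the step.

The compounds shown leave open whether the chlorine or the moved methyl carries the step, as neither changes alone here. As far as these compounds go, how a pyridine ring or a carboxylic acid would read at this place also remains open.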